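The source may report more compounds than this note shows. Statements on the series, on what has been measured and on what is new or still open speak of the compounds shown alone.

Compound 2, drawn as `O=C(NC[C@H]1CCCC[C@H]1O)NC1CCN(Cc2ccn(-c3ccc(C(F)(F)F)cc3)c2)CC1`, is the second highest of the three numbers in an assay on HEK293 cells for displacement of a labelled ligand from melanin-concentrating hormone receptor 1 (Homo sapiens); on this read-out higher numbers stand for weaker inhibition and lower numbers for stronger inhibition: compound 1 `O=C(NC1CCN(Cc2ccn(-c3ccc(C(F)(F)F)cc3)c2)CC1)NS(=O)(=O)c1ccc(F)cc1` gives 617 nM, compound 3 `CN1CCN(C(=O)NC2CCN(Cc3ccn(-c4ccc(C(F)(F)F)cc4)c3)CC2)C(c2ccccc2)C1` gives 28 nM, and compound 2 itself gives 63 nM. Among the measured compounds shown here, the one step measured so far, a 9.8-fold lower number from compound 1 to compound 2 (0.99 log units; beyond the scatter), swaps one whole group for another. Compound 4 `O=C(NC[C@@H]1CCCC[C@H]1O)NC1CCN(Cc2ccn(-c3ccc(C(F)(F)F)cc3)c2)CC1` is a different case: the two compounds have the same atoms and bonds and differ only in configuration as drawn: 1 of 2 stereo elements differ; a stereocentre at a saturated ring carbon is drawn R in compound 2 and S in compound 4. For the measured compounds named here, no measured step in this set changes only a configuration, so there is no direct guide to the size of the effect; a change confined to one stereocentre is expected to move the number less than a group swap did. The step from compound 2 to compound 4 is therefore estimated as a 1.6-fold higher number from compound 2 to compound 4 (0.20 log units; within the scatter), in no strongly preferred direction. Compound 4 is expected to give about 100 nM, within 30 nM to 320 nM.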

Compound 4, half-maximal inhibitory concentration: 46 nM
Beside the measured number, compound 4's estimate is 2.2-fold (0.34 log units) above it, within the range that was stated.
By their numbers in this assay, from the lowest: compounds 3, 4 and 2 (each within the scatter of the next, the first and the last beyond it); then compound 1.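

In this assay, inverting this stereocentre at a saturated ring carbon gives a 1.4-fold lower number from compound 2 to compound 4 (0.14 log units; within the scatter), so the change stays within the scatter and neither configuration can be ranked above the other. The (2-hydroxycyclohexyl)methyl group keeps its advantage over (4-fluorophenyl)sulfonyl with this configuration too, at a 13-fold lower number from compound 1 to compound 4 (1.13 log units; beyond the scatter). Among the compounds shown here, this is the first step in the set that isolates configuration alone: the fact that compounds 2 and 4 differ only in the configuration as drawn.

As far as these compounds go, what inverting the other stereocentre would do remains open. So does whether an amine or a carboxylic acid in place of the hydroxy group would hold the number.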